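Swapping the sulfonamide heteroaryl on a quinoline thiourea scaffold

The source may report more compounds than this note shows. Statements on the series, on what has been measured and on what is new or still open speak of the compounds shown alone.

Measured so far:
compound 1 `O=S(=O)(Nc1nccs1)c1ccc(N/C(S)=N\c2ccnc3cc(C(F)(F)F)ccc23)cc1` — 27200 nM
compound 2 `Cc1ccnc(NS(=O)(=O)c2ccc(N/C(S)=N\c3ccnc4cc(C(F)(F)F)ccc34)cc2)n1` — 31000 nM

Both compounds share a thiourea-linked core and differ only in the heteroaryl group on the sulfonamide nitrogen. Among the measured compounds shown here, in a functional assay on AS49-RAW cells (Homo sapiens) for antiproliferative activity, read by sulforhodamine B assay, with a stated time of 48 h (on this read-out higher numbers stand for weaker inhibition and lower numbers for stronger inhibition), compound 2 gives 31000 nM, the highest of the two numbers, and the only neighbour is compound 1, which lies within the scatter: a 1.1-fold higher number from compound 1 to compound 2 (0.06 log units; within the scatter).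

Compound 3 `COc1cc(NS(=O)(=O)c2ccc(N/C(S)=N\c3ccnc4cc(C(F)(F)F)ccc34)cc2)nc(OC)n1` carries the change (2,6-dimethoxypyrimidin-4-yl in place of 4-methylpyrimidin-2-yl on a sulfonamide nitrogen). For the measured compounds named here, the one step that bears on this position, from compound 1 to compound 2, replaced one heteroaryl by another on the same sulfonamide nitrogen and moved the number by a 1.1-fold higher number from compound 1 to compound 2 (0.06 log units; within the scatter), which is within the scatter. Going by the values given here, with only that step as a guide, and no measured compound carrying a methoxy-substituted pyrimidine, the expected step in this assay from compound 2 to compound 3 is none beyond the scatter, so a 1.1-fold lower number from compound 2 to compound 3 (0.03 log units; within the scatter) is the estimate. Compound 3 is therefore expected to give about 29000 nM, within a range from 10000 nM to 85000 nM.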

Compound 3, half-maximal inhibitory concentration: 64500 nM
Compound 3: middle estimate off by 2.2-fold (0.35 log units), on the low side; measured number inside the range.
By their numbers in this assay, from the lowest: compounds 1 and 2 (each within the scatter of the next); then compound 3.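

In this assay, the sulfonamide nitrogen turns out not to be indifferent to the heteroaryl group it carries: 2,6-dimethoxypyrimidin-4-yl in place of 4-methylpyrimidin-2-yl gives a 2.1-fold higher number from compound 2 to compound 3 (0.32 log units; beyond the scatter) and in place of 1,3-thiazol-2-yl gives a 2.4-fold higher number from compound 1 to compound 3 (0.37 log units; beyond the scatter) so both steps point towards weaker inhibition, though each is modest. The exchange of the two smaller groups had stayed at a 1.1-fold higher number from compound 1 to compound 2 (0.06 log units; within the scatter) and so the three compounds show that one heteroaryl swap at this position can leave the number in place while another moves it beyond the scatter. No measurement accompanies these compounds that could account for the shift.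

The change brings in the two methoxy groups and moves from a pyrimidin-2-yl to a pyrimidin-4-yl group in one step, so these compounds cannot tell which of the two goes with the weaker inhibition. As far as these compounds go, a plain pyrimidin-4-yl group or a 2,6-dimethylpyrimidin-4-yl group would separate them, and whether any group on this nitrogen, such as a simple phenyl ring or an aminopyridine, gives stronger inhibition than compounds 1 and 2 remains open.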